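Series notes: the step to compound 3

The compounds below may be only part of what the source reports. "The series", "measured", "known", "first", "only" and "open" are said of these compounds alone.

In a functional assay on PC-3 cells (Homo sapiens) for cytotoxicity, read by MTT assay, with a stated time of 72 h (on this read-out higher numbers stand for weaker inhibition and lower numbers for stronger inhibition), compound 1 (`CNC(=O)c1cc(Oc2ccc(C(=O)/C=C/c3ccc(Cl)c(Cl)c3)cc2)ccn1`) gives 8260 nM and compound 2 (`CNC(=O)c1cc(Oc2ccc(C(=O)/C=C/c3ccc(F)cc3Cl)cc2)ccn1`) gives 4760 nM on the same read-out. These two values lie within the scatter of each other, so compound 2 cannot be separated from compound 1 on the numbers shown. Compound 3 (`CNC(=O)c1cc(Oc2ccc(C(=O)/C=C/c3ccc(C#N)cc3)cc2)ccn1`) is not yet measured and differs from compound 2 by 4-cyanophenyl in place of 2-chloro-4-fluorophenyl on a double-bonded chain carbon bound to a double-bonded chain carbon in one place: 4-cyanophenyl in place of 2-chloro-4-fluorophenyl on a double-bonded chain carbon bound to a double-bonded chain carbon. Among the measured compounds shown here, one measured step bears on this change, a 1.7-fold lower number from compound 1 to compound 2 (0.24 log units; within the scatter) at the same place, and it stays within the scatter. For the measured compounds named here, no measured compound carries 4-cyanophenyl, so that single step is only indirect evidence and the direction remains open. In this assay no step beyond the scatter is expected, and the estimated step is a 1.3-fold higher number from compound 2 to compound 3 (0.11 log units; within the scatter) as a middle position between the two measured values. The value estimated for compound 3 is 6200 nM within an expected range of 2200 nM to 17000 nM on this evidence.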

Compound 3, half-maximal inhibitory concentration: 3870 nM
Compound 3: middle estimate off by 1.6-fold (0.20 log units), on the high side; the range from low to high includes it.
By their numbers in this assay, from the lowest: compounds 3, 2 and 1 (each within the scatter of the next, the first and the last beyond it).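

In this assay, the place on a double-bonded chain carbon bound to a double-bonded chain carbon now carries a ring without halogen, and 4-cyanophenyl cannot be separated from 2-chloro-4-fluorophenyl, with a 1.2-fold lower number from compound 2 to compound 3 (0.09 log units; within the scatter). Against 3,4-dichlorophenyl the same place gives its first step beyond the scatter, a 2.1-fold lower number from compound 1 to compound 3 (0.33 log units; beyond the scatter), although this step is modest and compound 2 remains within the scatter of both other compounds. No measurement at hand accounts for the differences among these three groups.

What the nitrile itself contributes remains open, as the compounds shown do not separate it from the loss of the halogens, and a plain phenyl, an aminophenyl or a carboxyphenyl at this place would test that directly. Also open, as far as these compounds go, is whether the modest step from 3,4-dichlorophenyl to 4-cyanophenyl holds on a core other than the shared one, or in a cell line other than the one used here.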